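Working notes on two measured analogues and a third

A few compounds are considered here, and "the series" means these few. Any claim that something is new, unique, unknown or untested is made for them only; others in the source may bear on it.

Measured so far:
compound 1 `C=CCn1c(=O)/c(=C\c2ccccc2Cl)[nH]c(=O)/c1=C\c1ccccc1OC` — 5100 nM
compound 2 `C=CCn1c(=O)/c(=C\c2ccccc2OC)[nH]c(=O)/c1=C\c1ccccc1OC` — 6900 nM

In a functional assay on HeLa cells (Homo sapiens) for cytotoxicity, read by CCK-8 assay, with a stated time of 72 h (a higher number here means a weaker inhibitor, a lower number a stronger inhibitor), compound 2 gives 6900 nM. Of the two numbers shown it is the one with the higher value, but the only other compound, compound 1, lies within the usual scatter of it: a 1.4-fold higher number from compound 1 to compound 2 (0.13 log units; within the scatter). Nothing in these two numbers separates compound 1 from compound 2.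

Compound 3 `C=CCn1c(=O)/c(=C\c2ccccc2C(F)(F)F)[nH]c(=O)/c1=C\c1ccccc1OC` differs from compound 2 at one place: trifluoromethyl in place of methoxy on an aromatic carbon. Going by the values given here, the single measured step, a 1.4-fold higher number from compound 1 to compound 2 (0.13 log units; within the scatter), concerns the same position of the same shared core and was within the scatter, so it gives no sign that what sits at this aromatic carbon moves the number much. Among the compounds with values here, there is no measured step involving a trifluoromethyl group, so the expectation rests on compound 2 alone and on the smallness of the one step observed.

Compound 3 is therefore expected to show a 1.1-fold lower number from compound 2 to compound 3 (0.03 log units; within the scatter), a step not beyond the scatter. The estimate for compound 3 in this assay is 6500 nM, with a range from 2500 nM to 17000 nM.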

Compound 3, half-maximal inhibitory concentration: 4600 nM
Beside the measured number, compound 3's estimate is 1.4-fold (0.15 log units) above it; the measured number falls inside the stated range.
By their numbers in this assay, from the lowest: compounds 3, 1 and 2 (each within the scatter of the next).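

In this assay, this aromatic carbon of the shared core now carries a third group, and trifluoromethyl stays within the scatter of both earlier groups, methoxy (a 1.5-fold lower number from compound 2 to compound 3 (0.18 log units; within the scatter)) and chloro (a 1.1-fold lower number from compound 1 to compound 3 (0.04 log units; within the scatter)). The earlier compounds shown here offered only the comparison of chloro with methoxy, whereas compound 1, compound 2 and compound 3 now show that three groups at this place cannot be told apart by this read-out, even though the 2-methoxyphenyl to 2-(trifluoromethyl)phenyl change takes the group from 2 heavy atoms to 4 and from 1 hydrogen-bond acceptor to 0. This is a statement about these three groups only, and no available evidence bears on why they read alike.

From the compounds shown here alone, it remains open whether a group of another kind on this aromatic carbon, such as an amine, a carboxylic acid or a longer chain, would give a step beyond the scatter. The compounds shown also share everything outside this position, so they say nothing about how the number responds to changes elsewhere on the shared core.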